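Inverting the stereocentre of the 1-carboxy-2-methylpropyl amide

The source may report more compounds than this note shows. Statements on the series, on what has been measured and on what is new or still open speak of the compounds shown alone.

Among the compounds with values here, in a functional assay on PC-3 cells (Homo sapiens) for antiproliferative activity, read by MTT assay, with a stated time of 24 h (on this read-out lower numbers stand for stronger inhibition and higher numbers for weaker inhibition), only two numbers exist so far. Compound 1 `CCn1c(C(=O)N[C@H](CO)CCO)ccc1C(CC)(CC)c1ccc(OCS(=O)(=O)c2ccccc2)c(C)c1` gives 12100 nM, and compound 2 `CCn1c(C(=O)N[C@H](C(=O)O)C(C)C)ccc1C(CC)(CC)c1ccc(OCS(=O)(=O)c2ccccc2)c(C)c1` gives 3650 nM, the lower of the two. Within the data shown here, the single measured step is a 3.3-fold lower number from compound 1 to compound 2 (0.52 log units; beyond the scatter), with 1-carboxy-2-methylpropyl in place of 3-hydroxy-1-(hydroxymethyl)propyl on an amide-type nitrogen.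

Compound 3 `CCn1c(C(=O)N[C@@H](C(=O)O)C(C)C)ccc1C(CC)(CC)c1ccc(OCS(=O)(=O)c2ccccc2)c(C)c1` has the same atoms and bonds as compound 2: the two compounds have the same atoms and bonds and differ only in configuration as drawn: 1 of 1 stereo elements differ; a stereocentre at a saturated chain carbon is drawn S in compound 2 and R in compound 3. A stereocentre at a saturated chain carbon is drawn S in compound 2 and R in compound 3.

Among the measured compounds shown here, no measured pair tests a change of configuration, so the data give neither the size nor the direction of this step directly. The nearest guide is the modest change in a 3.3-fold lower number from compound 1 to compound 2 (0.52 log units; beyond the scatter), which involves the same amide substituent but replaces the group outright. The best guess is therefore no shift beyond the scatter, though a shift of that modest size in this assay remains possible, more likely upward. The expected step is a 1.2-fold higher number from compound 2 to compound 3 (0.09 log units; within the scatter). For compound 3 the estimated value is 4500 nM, with an expected range from 1800 nM to 12000 nM.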

Compound 3, half-maximal inhibitory concentration: 3070 nM
Estimate against measurement, compound 3: 1.5-fold (0.17 log units) above, and the stated range covers the measured number.
By their numbers in this assay, from the lowest: compounds 3 and 2 (each within the scatter of the next); then compound 1.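

In this assay, the configuration at the stereocentre of the 1-carboxy-2-methylpropyl amide makes no difference that can be told from the scatter, with a 1.2-fold lower number from compound 2 to compound 3 (0.08 log units; within the scatter). Within the data shown here, the one earlier step replaced the whole amide substituent and said nothing about configuration, whereas this pair isolates a single structural variable: the fact that compounds 2 and 3 differ only in the configuration as drawn. The lower number relative to the 3-hydroxy-1-(hydroxymethyl)propyl amide also holds for the other drawn configuration, with a 3.9-fold lower number from compound 1 to compound 3 (0.60 log units; beyond the scatter), so within these compounds the advantage of the 1-carboxy-2-methylpropyl group does not depend on how this stereocentre is drawn.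

From the compounds shown here alone, whether that advantage belongs to the carboxylic acid or to the branched chain stays open, as the 1-carboxy-2-methylpropyl group replaces the whole substituent in one step. A methyl ester in place of the carboxylic acid, or a longer chain in place of the branched one, would put each part of the group to a separate test, in either configuration at the stereocentre.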